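Swapping a methoxyphenyl for an indole: expected cell toxicity

The compounds below may be only part of what the source reports. "The series", "measured", "known", "first", "only" and "open" are said of these compounds alone.

Compound 2 `COc1cccc(-c2ccc(C(=O)N(Cc3cccc(OCCCCCC(=O)O)c3)C(C)C)cc2)c1` has been tested in an ADME assay on HEK293 cells (Homo sapiens) for cytotoxicity, read by CellTiter-Glo and resazurin assay, with a stated time of 72 h; a lower number here means that less compound is needed, a higher number that more compound is needed for the effect. In this assay compound 2 gives > 20900 nM, which is a limit of the assay rather than a measured number. Its closest measured relative is compound 1 `CC(C)Oc1cccc(-c2ccc(C(=O)N(Cc3cccc(OCCCCCC(=O)O)c3)C(C)C)cc2)c1`. In this assay compound 1 gives > 26000 nM, again a limit. Within the data shown here, the one measured step, a step that the two limits leave unreadable from compound 1 to compound 2, stays unreadable because the limit of > 20900 nM in this assay, at which 1 of the 2 values shown sits, and the limit of > 26000 nM in this assay, at which 1 of the 2 values shown sits, both mark limits. Compound 3 `CC(C)N(Cc1cccc(OCCCCCC(=O)O)c1)C(=O)c1ccc(-c2ccc3[nH]ccc3c2)cc1` is not yet measured. It differs from compound 2 by 1H-indol-5-yl in place of 3-methoxyphenyl on an aromatic carbon. Among the measured compounds shown here, no measured step touches this kind of change, and the single step available gives neither a size nor a direction. For compound 3 the expected outcome in this assay is another limit, estimated at 30000 nM with a range from 10000 nM to 100000 nM. The step that the limit leaves unreadable from compound 2 to compound 3 is expected, which means no change beyond the scatter.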

Compound 3, half-maximal effective concentration: > 26000 nM
Compound 3: only a limit was reported (the forecaster's own chance of this, stated with the estimate: 75%); the middle value lies beyond the limit too.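

Among these compounds, compound 3, like compound 1 and compound 2, gives only a limit in this assay, so no step among the three can be read. The compounds shown leave open how much of each is needed for the effect, and whether swapping 3-methoxyphenyl for 1H-indol-5-yl changes that amount.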